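This account rests on a few compounds, and the source may have more. Where it says the series, first, only, none or still open, it means among the compounds named here.

Working notes on the series in a functional assay on KB cells (Homo sapiens) for cytotoxicity, read by sulforhodamine B assay, with a stated time of 48 h; on this read-out lower numbers stand for stronger inhibition of growth and higher numbers for weaker inhibition of growth. Compound 1 `Cc1cnc(NC(=O)COc2ccc(/C=C3\SC(=O)NC3=O)cc2)s1` reaches only a limit, < 100000 nM. Compound 2 `O=C(COc1ccc(/C=C2\SC(=O)NC2=O)cc1)Nc1nc2ccccc2s1` likewise gives only a limit, < 100000 nM. Compound 3 `O=C1NC(=O)/C(=C\c2ccc(OCC(=O)N3C(=O)c4ccccc4S3(=O)=O)cc2)S1` also sits at a limit, < 100000 nM. Within the data shown here, the one step with a single change, a step that the two limits leave unreadable from compound 1 to compound 2, cannot be sized, since the limit of < 100000 nM in this assay, at which 3 of the 3 values shown sit, covers every value shown. Compound 4 `O=C(COc1ccc(/C=C2\SC(=O)NC2=O)cc1)Nc1ccccn1` differs from compound 2 by pyridin-2-yl in place of 1,3-benzothiazol-2-yl on an amide-type nitrogen. Among the measured compounds shown here, no measured step bears on this change, and this assay has yielded no number at all, so the expected size of the step from compound 2 to compound 4 is a step that the limit leaves unreadable from compound 2 to compound 4, with a further limit the most likely outcome. Compound 4 is estimated at 30000 nM, between 5000 nM and 100000 nM.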

Compound 4, concentration for 50% growth inhibition: < 100000 nM
Compound 4: no number, only a limit (the forecaster's own chance of this, stated with the estimate: 70%); the middle value is on the limit's open side.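

Neither new step, from compound 1 or from compound 2 to compound 4, can be read: the limit of < 100000 nM in this assay, at which 4 of the 4 values shown sit.

The compounds shown leave open how strongly each inhibits growth, and whether the group on the amide-type nitrogen matters at all.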